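The source may report more compounds than this note shows. Statements on the series, on what has been measured and on what is new or still open speak of the compounds shown alone.

Compound 1 `Cc1ccn(Cc2c(F)cccc2F)c2nc(-c3c(F)cccc3F)nc1-2`: > 100000 nM
Compound 2 `COc1ccccc1Cn1ccc2nc(-c3ccccc3)nc-2c1`: > 100000 nM

Of the compounds shown here, two have been measured in an ADME assay on MDBK cells (Bos taurus) for cytotoxicity; on this read-out higher numbers stand for lower toxicity in this test and lower numbers for higher toxicity in this test. For compound 1 the value > 100000 nM is a limit of the assay, not a number. For compound 2 the value > 100000 nM is likewise a limit and not a number. Compound 2 therefore stands at the limit of > 100000 nM in this assay, at which 2 of the 2 values shown sit, and compound 1 sits at the same limit, so the two measurements do not separate them. The untested compound 3 `Clc1ccc(Cn2ccc3nc(-c4ccccc4)nc-3c2)cc1Cl` keeps the core of compound 2 and differs from it in a single place: 3,4-dichlorophenyl in place of 2-methoxyphenyl on a saturated chain carbon bound to an aromatic nitrogen. Among the compounds with values here, no pair of measured compounds shows what such an exchange does in this assay, and both measured values are limits rather than numbers, so the step that is expected here is one of no change beyond the usual scatter: a number no higher from compound 2 to compound 3 (the limit leaves the size open). Compound 3 is thus expected to give about 100000 nM, within a range from 30000 nM to 300000 nM, and most probably to be reported again only as a limit.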

Compound 3, half-maximal cytotoxic concentration: 71000 nM
Beside the measured number, compound 3's estimate is 1.4-fold (0.15 log units) above it; measured number inside the range.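

In this assay, compound 3 is the first of the compounds shown to give a number rather than a limit, so a read-out can now be placed on a group at this position, on a saturated chain carbon bound to an aromatic nitrogen. Exchanging 2-methoxyphenyl for 3,4-dichlorophenyl there gives an at least 1.4-fold lower number from compound 2 to compound 3 (0.14 log units; that floor lies within the scatter), and since that floor lies within the scatter, it does not establish a real change in toxicity in this test. The true size of the step stays unknown because compound 2 gives only a limit and not a number: the limit of > 100000 nM in this assay, at which 2 of the 3 values shown sit.

The exchange removes the methoxy group and brings in two chlorines at once, so the compounds shown cannot say how much either part contributes, or whether a single chlorine would give a number at all. They also leave open how this assay responds to a ring carrying an amine or a carboxylic acid at this place, or to a longer chain ahead of the ring.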